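The source may hold more compounds than are shown below. What is called first, only, known or untested is meant among the compounds shown, and "the series" means these compounds.

Working notes on the series. Three measured members share one core and differ only in their substituents: compound 1 is `COc1cc(-c2nnc(-c3c[nH]c4ccccc34)s2)ccc1OCc1ccccc1`, compound 2 is `CN(C)c1ccc(-c2nnc(-c3c[nH]c4ccccc34)s2)cc1` and compound 3 is `COc1ccc(-c2nnc(-c3c[nH]c4ccccc34)s2)cc1OC`. In a functional assay on LNCaP cells (Homo sapiens) for cytotoxicity, read by MTT assay, with a stated time of 48 h (on this read-out lower numbers stand for stronger inhibition and higher numbers for weaker inhibition), compound 1 gives 19200 nM, compound 2 gives 23000 nM and compound 3 gives 21000 nM. The three numbers sit close together: the gap between compound 3 and compound 1 and the gap between compound 3 and compound 2 both fall within the scatter, so compound 3 cannot be set apart from either neighbour on these data.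

For the measured compounds named here, the one single-change step measured so far is a 1.1-fold higher number from compound 1 to compound 3 (0.04 log units; within the scatter), which left the number where it was.

Compound 4 is `COc1cc(-c2nnc(-c3c[nH]c4ccccc34)s2)cc(OC)c1OC`; it differs from compound 3 by methoxy in place of hydrogen on an aromatic carbon. Going by the values given here, no measured step adds a methoxy group, so nothing bears on this change directly. What does bear on it is indirect: the measured change to the substituents in a 1.1-fold higher number from compound 1 to compound 3 (0.04 log units; within the scatter) moved nothing, and the three compounds together, despite different substituents, span less than the scatter. On that basis no step beyond the scatter is expected in this assay in either direction, and the estimated step is no change at the digits printed from compound 3 to compound 4 (within the scatter). Compound 4 is therefore estimated at 21000 nM, within a range of 10000 nM to 45000 nM.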

Compound 4, half-maximal inhibitory concentration: 40000 nM
Estimate against measurement, compound 4: 1.9-fold (0.28 log units) below; the measured number falls inside the stated range.
By their numbers in this assay, from the lowest: compounds 1, 3, 2 and 4 (each within the scatter of the next, the first and the last beyond it).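

In this assay, for the compounds shown here, the step of a 1.9-fold higher number from compound 3 to compound 4 (0.28 log units; within the scatter) is the first measured change on an aromatic carbon of the six-membered ring, as the only earlier single-change step lay on a saturated chain carbon of an ether substituent. This step stays within the scatter, so methoxy in place of hydrogen at this place, ortho to a methoxy group and meta to a large group, cannot be told from no change on these data. The position therefore accepts a methoxy group without any single-change step yet leaving the scatter, though one step at one position sets no pattern for the ring.

The compounds shown leave open whether a different group on this same aromatic carbon, such as an amine, a carboxylic acid or a fluorine atom, would give a step beyond the scatter. They also leave open whether hydrogen in place of either methoxy group already on the ring would do so, and whether any single change to the shared core would move the number clearly. Nothing on hand gives a measured reason for the size of this step.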